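Urea series: nitro to trifluoromethyl on the alcohol core

The compounds below may be only part of what the source reports. "The series", "measured", "known", "first", "only" and "open" are said of these compounds alone.

Measured so far:
compound 1 `CN1c2ccc(NC(=O)Nc3ccc([N+](=O)[O-])cc3)cc2C(C)(C)C(=O)C1(C)C` — 300 nM
compound 2 `CN1c2ccc(NC(=O)Nc3ccc(C(F)(F)F)cc3)cc2C(C)(C)C(=O)C1(C)C` — 1500 nM
compound 3 `CN1c2ccc(NC(=O)Nc3ccc([N+](=O)[O-])cc3)cc2C(C)(C)C(O)C1(C)C` — 1600 nM

In an assay on isolated protein for binding affinity to stress-70 protein, mitochondrial (Homo sapiens) (a higher number here means weaker binding, a lower number tighter binding), compound 1 gives 300 nM on the ketone-bearing core. Compound 2 differs from compound 1 by trifluoromethyl in place of nitro on an aromatic carbon; in this assay compound 2 gives 1500 nM, and the step is a 5.0-fold higher number from compound 1 to compound 2 (0.70 log units; beyond the scatter). Compound 3 carries the same aryl urea on a core whose difference from the core of compound 1 is not broken down here; in this assay compound 3 gives 1600 nM, a higher number than compound 1.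

Compound 4 `CN1c2ccc(NC(=O)Nc3ccc(C(F)(F)F)cc3)cc2C(C)(C)C(O)C1(C)C` has not yet been measured. Going by the values given here, it differs from compound 3 by trifluoromethyl in place of nitro on an aromatic carbon, the same change as the one from compound 1 to compound 2, at the same place on the ring. Among the compounds with values here, the step is expected to resemble that one, since the only measured instance, a 5.0-fold higher number from compound 1 to compound 2 (0.70 log units; beyond the scatter), weakened binding; the different core of compound 3 leaves the size uncertain. The estimated step is a 3.8-fold higher number from compound 3 to compound 4 (0.57 log units; beyond the scatter). Compound 4 is therefore expected to give about 6000 nM in this assay, plausibly between 2500 nM and 15000 nM.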

Compound 4, dissociation constant: 700 nM
Estimate against measurement, compound 4: 8.6-fold (0.93 log units) above; the whole stated range lies above it.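

In this assay, trifluoromethyl in place of nitro gives a 2.3-fold lower number from compound 3 to compound 4 (0.36 log units; beyond the scatter), so the change does not carry from one core to the other with the same direction or size: the same change on two cores in this assay, a 5.0-fold higher number (0.70 log units; beyond the scatter) from compound 1 to compound 2 and a 2.3-fold lower number (0.36 log units; beyond the scatter) from compound 3 to compound 4, 11-fold (1.06 log units) apart, beyond the scatter of two such steps

In these two pairs, the outcome of the change depends on the core, and the step measured on the core of compound 1 cannot simply be applied to the core of compound 3. The two pairs do not show why the steps part, nor whether this reversal extends to any other aryl group or core.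

Open, from the compounds shown here alone, is how a nitrile, chlorine or an amine in place of nitro or trifluoromethyl would behave on each of the two cores. Also open, going by these compounds, is whether an amine or a methoxy group in place of the hydroxyl on the core of compound 3 would follow the pattern of compound 3 and compound 4 or that of compound 1 and compound 2.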